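A thiazolyl group replaces a triazolyl group on sulfur

The compounds below may be only part of what the source reports. "The series", "measured", "known", "first", "only" and "open" are said of these compounds alone.

Measured in a functional assay on KYSE-70 cells for antiproliferative activity against KYSE-70 cell line (Homo sapiens), read by MTT assay, with a stated time of 72 h; a higher number here means a weaker inhibitor, a lower number a stronger inhibitor:
- compound 1 `C#CCSc1nc(Sc2ccccn2)c(C#N)c(-c2cc(OC)c(OC)c(OC)c2)n1`: > 10000 nM, a limit
- compound 2 `C#CCSc1nc(Sc2nc[nH]n2)c(C#N)c(-c2cc(OC)c(OC)c(OC)c2)n1`: > 20000 nM, a limit
- compound 3 `C#CCSc1nc(Sc2nnnn2CCN(C)C)c(C#N)c(-c2cccc(Cl)c2)n1`: 5320 nM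

In this assay, compound 2 stands only at a limit, > 20000 nM. Compound 4 `C#CCSc1nc(Sc2nc(C)cs2)c(C#N)c(-c2cc(OC)c(OC)c(OC)c2)n1` carries 4-methyl-1,3-thiazol-2-yl in place of 1H-1,2,4-triazol-3-yl on a sulfur. Among the compounds with values here, the one measured step at this place, a step that the two limits leave unreadable from compound 1 to compound 2, offers no size to carry over. Compound 3 alone has a number, 5320 nM, but it differs from compound 2 in more than one place. Only a weak compound is therefore expected, possibly reported as a limit again. The expected step, an at least 1.6-fold lower number from compound 2 to compound 4 (0.22 log units; that floor lies within the scatter), is toward stronger inhibition but remains uncertain. For compound 4 the estimate is 12000 nM, with an expected range of 4000 nM to 30000 nM.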

Compound 4, half-maximal inhibitory concentration: > 20000 nM
Compound 4 ended at the assay's limit; the forecaster's own chance of this, stated with the estimate: 55%; middle value at least 1.6-fold (0.22 log units) away from the limit.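

Compound 1, compound 2 and compound 4 all stand at limits of the assay, and the steps among them cannot be read. On these data alone, whether their three groups on sulfur differ at all in activity stays open.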